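The source may hold more compounds than are shown below. What is called first, only, known or untested is meant among the compounds shown, and "the series" means these compounds.

Within the data shown here, the three compounds measured so far share one core and differ only at one ring carbon. Compound 1 `Nc1scc(-c2cccc(C(F)(F)F)c2)c1C(=O)c1ccccc1` carries a hydrogen at that position, and in an assay on CHO-K1 cells for displacement of a labelled ligand from adenosine receptor A1 (Homo sapiens), tested at 10 uM (on this read-out higher numbers stand for more inhibition at the one concentration tested (going by the name of the read-out) and lower numbers for less inhibition), compound 1 gives 61.1%. Compound 2 `Nc1sc(-c2ccccc2)c(-c2cccc(C(F)(F)F)c2)c1C(=O)c1ccccc1` carries a phenyl there, and in this assay compound 2 gives 82.4%. Compound 3 `Nc1sc(-c2ccc([N+](=O)[O-])cc2)c(-c2cccc(C(F)(F)F)c2)c1C(=O)c1ccccc1` carries a 4-nitrophenyl there, and in this assay compound 3 gives 34.8%. Among these three numbers compound 1 stands second highest: it is exceeded by compound 2, a number 21.3 percentage points higher from compound 1 to compound 2 (beyond the scatter), and it exceeds compound 3, a number 26.3 percentage points lower from compound 1 to compound 3 (beyond the scatter). Between the two aryl-bearing compounds the step is large, a number 47.6 percentage points lower from compound 2 to compound 3 (beyond the scatter).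

Compound 4 `COc1ccc(-c2sc(N)c(C(=O)c3ccccc3)c2-c2cccc(C(F)(F)F)c2)cc1` differs from compound 1 in a single place: 4-methoxyphenyl in place of hydrogen on an aromatic carbon. The two measured steps that bear on this change pull in opposite directions, one upward, a number 21.3 percentage points higher from compound 1 to compound 2 (beyond the scatter), and one downward, a number 26.3 percentage points lower from compound 1 to compound 3 (beyond the scatter). Among the measured compounds shown here, a 4-methoxyphenyl is, like the 4-nitrophenyl, a phenyl bearing one substituent, but no measured compound shows what a methoxy group does at this position. The expected step is therefore small, a number 6.9 percentage points higher from compound 1 to compound 4 (within the scatter), and is expected to stay within the scatter. Compound 4 is estimated to give 68% in this assay, with an expected range from 45% to 88%.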

Compound 4, a percentage reported as inhibition, at one concentration (the size of the read-out at that concentration, not a potency): 65.2%
Estimate against measurement, compound 4: 2.8 percentage points above; the measured number falls inside the stated range.
By their numbers in this assay, from the lowest: compound 3; then compounds 1 and 4 (each within the scatter of the next); then compound 2.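

Putting a 4-methoxyphenyl on the aromatic carbon next to the ring sulfur leaves the read-out in this assay close to that of the hydrogen it replaces (a number 4.1 percentage points higher from compound 1 to compound 4 (within the scatter)), so a phenyl bearing one substituent at this position does not have to bring the loss seen with the 4-nitrophenyl. What the phenyl carries clearly matters: exchanging nitro for methoxy on that ring gives a clear change (a number 30.4 percentage points higher from compound 3 to compound 4 (beyond the scatter)), and adding methoxy to the plain phenyl also gives one (a number 17.2 percentage points lower from compound 2 to compound 4 (beyond the scatter)), so both substituted phenyls shown stand under the plain phenyl, the methoxy by a smaller step than the nitro (a number 47.6 percentage points lower from compound 2 to compound 3 (beyond the scatter)). No measurement offered here explains why these two groups differ.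

With only methoxy and nitro on this phenyl, two substituents cannot show what rule, if any, orders them, and a chlorine, an amine or a carboxylic acid on the same ring could fall anywhere relative to them. Going by these compounds, it also remains open whether methoxy would behave the same way elsewhere on the phenyl, and whether a methyl or a longer chain directly on the ring carbon could replace the phenyl altogether.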